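Swapping a hydroxy cyclohexyl for a carbamoyl cyclobutyl

The source may report more compounds than this note shows. Statements on the series, on what has been measured and on what is new or still open speak of the compounds shown alone.

Of the compounds shown here, three sharing one core have been measured in an assay on isolated protein for inhibition of protein kinase C theta type (Homo sapiens), read by TR-FRET, with a stated time of 2 h; a lower number here means a stronger inhibitor, a higher number a weaker inhibitor. Compound 1 `N#Cc1cnc(NCc2cnccc2C(F)(F)F)cc1NC[C@H]1CC[C@@H](O)CC1` gives 58 nM in this assay. Compound 2 `N#Cc1cnc(NCc2cnccc2C(F)(F)F)cc1N[C@H]1CC[C@@H](C(N)=O)CC1` gives 7 nM, and compound 3 `CC1(C)C[C@@H](Nc2cc(NCc3cnccc3C(F)(F)F)ncc2C#N)CC[C@@H]1O` gives 120 nM. Compound 3 therefore stands at the highest number of the three: the step of a 2.1-fold higher number from compound 1 to compound 3 (0.32 log units; beyond the scatter) was modest, while the step of a 17-fold higher number from compound 2 to compound 3 (1.23 log units; beyond the scatter) was large.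

The next compound, compound 4 `CC1(C)[C@@H](Nc2cc(NCc3cnccc3C(F)(F)F)ncc2C#N)C[C@H]1C(N)=O`, is not yet measured. It differs from compound 3 by 3-carbamoyl-2,2-dimethylcyclobutyl in place of 4-hydroxy-3,3-dimethylcyclohexyl on a nitrogen on an aromatic ring.

Among the compounds with values here, two measured steps bear on this change. The step of an 8.3-fold lower number from compound 1 to compound 2 (0.92 log units; beyond the scatter) shows that a carbamoyl on the ring in place of a hydroxyl gave a clearly lower number, and the step of a 17-fold higher number from compound 2 to compound 3 (1.23 log units; beyond the scatter) shows the reverse exchange, with added dimethyl, gave a much higher one. Compound 4 keeps the carbamoyl of compound 2 and the dimethyl of compound 3, but on a four-membered ring for which no measurement exists. A lower number than that of compound 3 is expected in this assay, though the ring change leaves the size uncertain. The step from compound 3 to compound 4 is estimated as a 4.0-fold lower number from compound 3 to compound 4 (0.60 log units; beyond the scatter). Compound 4 is expected to give 30 nM in this assay, with a range from 8 nM to 120 nM.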

Compound 4, half-maximal inhibitory concentration: 140 nM
For compound 4 the middle estimate is 4.7-fold (0.67 log units) below the measured one, outside the stated range (above it).
By their numbers in this assay, from the lowest: compound 2; then compound 1; then compounds 3 and 4 (each within the scatter of the next).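

In this assay, the carbamoyl did not carry its earlier benefit over to the four-membered ring: 3-carbamoyl-2,2-dimethylcyclobutyl in place of 4-hydroxy-3,3-dimethylcyclohexyl gives a 1.2-fold higher number from compound 3 to compound 4 (0.07 log units; within the scatter), so at this position on the nitrogen the two groups cannot be told apart. A carbamoyl alone therefore does not secure a low number, since a 20-fold higher number from compound 2 to compound 4 (1.30 log units; beyond the scatter) is a large step between two groups that both carry one, and a 2.4-fold higher number from compound 1 to compound 4 (0.38 log units; beyond the scatter) places the new group on the weaker side of (4-hydroxycyclohexyl)methyl as well. No measurement given here explains this result, and the data offer no account of why the carbamoyl behaves differently on the two rings.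

The step to compound 4 changes the ring size and adds the two methyl groups together, so the compounds shown leave open how much of the large step belongs to each, which a cyclobutyl bearing the carbamoyl without the methyl groups, or a cyclohexyl bearing both, would separate. Also open, on these data alone, is whether a carboxylic acid or an amine in place of the carbamoyl on the cyclobutyl would read any differently.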